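The compounds below may be only part of what the source reports. "The series", "measured", "known", "first", "only" and "open" are said of these compounds alone.

Measured so far:
Compound 1 `CN1CCN(Cc2cn(Cc3ccc(F)cc3)c3cnc(C(=O)N(C)O)cc23)CC1`: > 224000 nM
Compound 2 `COCCOCc1cn(Cc2ccc(F)cc2)c2cnc(C(=O)N(C)O)cc12`: > 100000 nM

In an ADME assay on CEM-SS cells (Homo sapiens) for cytotoxicity, read by XTT assay (a lower number here means that less compound is tolerated, a higher number that more compound is tolerated), compound 2 gives > 100000 nM, which is a limit and not a number. Compound 1 gives > 224000 nM, which is also a limit. So neither compound has a readable value, and compound 2 cannot be ranked against compound 1.

Compound 3 `CC(C)NC(=O)c1cn(Cc2ccc(F)cc2)c2cnc(C(=O)N(C)O)cc12` keeps the shared core but has isopropylcarbamoyl in place of (2-methoxyethoxy)methyl on an aromatic carbon.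

Among the compounds with values here, only one measured step bears on this change: a step that the two limits leave unreadable from compound 1 to compound 2. There, 2-methoxyethoxy replaces 4-methylpiperazin-1-yl on a saturated chain carbon bound to an aromatic carbon. That step has no readable size to carry over, so it gives no direction either.

The expectation therefore rests on compound 2, with its limit of > 100000 nM, and this assay may well return only a limit again. The expected change is a number no higher from compound 2 to compound 3 (the limit leaves the size open), with no direction favoured. For compound 3 the estimate is 100000 nM, with an expected range from 30000 nM to 300000 nM.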

Compound 3, half-maximal cytotoxic concentration: > 100000 nM
Compound 3 gave a limit, no number; the forecaster's own chance of this, stated with the estimate: 70%; the middle value lies on the limit itself.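

In this assay compound 3 gives > 100000 nM, which is a limit and not a number. Within the data shown here, compound 1 and compound 2 also carry limits, so no step among compound 1, compound 2 and compound 3 can be read. The compounds shown leave open what half-maximal cytotoxic concentration any of them has in this assay, and whether they differ at all.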